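This account rests on a few compounds, and the source may have more. Where it says the series, first, only, none or still open, it means among the compounds named here.

Three close relatives of one shared core have been measured in a functional assay on A549 cells (Homo sapiens), read by MTT assay, with a stated time of 72 h; a lower number here means a stronger inhibitor, a higher number a weaker inhibitor. Compound 1 `Cc1ncnc2c1c(I)cn2[C@@H]1O[C@H](CO)[C@@H](O)[C@H]1O` gives 12200 nM in this assay, and compound 2 `C#Cc1cn([C@@H]2O[C@H](CO)[C@@H](O)[C@H]2O)c2ncnc(C)c12` gives 19200 nM. Compound 3 `C#Cc1cn([C@@H]2O[C@H](CO)[C@@H](O)[C@H]2O)c2ncnc(NC)c12` gives only > 20000 nM, which is a limit of this assay and not a number. Going by the values given here, of the two actual numbers, compound 2 carries the higher one, with compound 1 as its only neighbour; the step of a 1.6-fold higher number from compound 1 to compound 2 (0.20 log units; within the scatter) lies within the scatter, so the two cannot be told apart. The step of an at least 1.0-fold higher number from compound 2 to compound 3 (0.01 log units; that floor lies within the scatter) is likewise small, and it ends at the limit of > 20000 nM in this assay, at which 1 of the 3 values shown sits.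

Compound 4 `Cc1ncnc2c1c(-c1ccsc1)cn2[C@@H]1O[C@H](CO)[C@@H](O)[C@H]1O` differs from compound 2 in one place: thiophen-3-yl in place of ethynyl on an aromatic carbon. Among the compounds with values here, the only measured step at that same place, a 1.6-fold higher number from compound 1 to compound 2 (0.20 log units; within the scatter), hardly moved the number, and no measured compound carries a ring there, so the data give no direction for a larger group. The step of a 1.3-fold lower number from compound 2 to compound 4 (0.11 log units; within the scatter) is therefore expected to be small, with either direction possible. Compound 4 is estimated at 15000 nM, within a range of 5000 nM to 40000 nM.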

Compound 4, half-maximal inhibitory concentration: > 20000 nM
Compound 4 gave a limit, no number; the forecaster's own chance of this, stated with the estimate: 30%; at least 1.3-fold (0.12 log units) between middle value and limit.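

In this assay, compound 4 carries a five-membered aromatic ring, thiophen-3-yl, at this aromatic carbon, where compound 1 has iodo and compound 2 has ethynyl, and this larger group brings no lower number. The two steps give only floors, an at least 1.0-fold higher number from compound 2 to compound 4 (0.01 log units; that floor lies within the scatter) and an at least 1.6-fold higher number from compound 1 to compound 4 (0.21 log units; that floor lies within the scatter), so they show no drop but cannot show how large any rise is. The reading for compound 4 is a limit and not a number, so the ring result can be placed only at the edge of what this assay reports: the limit of > 20000 nM in this assay, at which 2 of the 4 values shown sit.

On these data alone, how far past that limit compound 4 lies stays unknown. Also open, as far as these compounds go, is whether a phenyl ring, an amine or a carboxylic acid on this carbon would give a lower number than iodo or ethynyl.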